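Swapping the Furan on Compound 1

The compounds below may be only part of what the source reports. "The series", "measured", "known", "first", "only" and "open" are said of these compounds alone.

Measured in a functional assay on MCF7 cells (Homo sapiens) for inhibition, read by MTT assay; a higher number here means a weaker inhibitor, a lower number a stronger inhibitor:
- compound 1 `O=C(CCCCCCC(=O)Nc1nnc(-c2ccco2)s1)NO`: 880 nM
- compound 2 `O=C(COc1ccc(C(=O)/C=C/c2ccccc2)cc1)NO`: 620 nM
- compound 3 `COc1ccc(-c2ocnc2-c2cc(Br)c(OC)c(OC)c2)cc1OCCCC(=O)NO`: 18 nM

Compound 1 and compound 2 lie within the scatter of each other, while compound 3 gives a far lower number than either. Compound 4 `Cc1ccc(-c2nnc(NC(=O)CCCCCCC(=O)NO)s2)s1` carries 5-methylthiophen-2-yl in place of furan-2-yl on an aromatic carbon. For the measured compounds named here, no measured pair shows this kind of change. The entering group is again one five-membered aromatic ring with 1 hetero atom, so compound 1, at 880 nM, is the reference, and no step beyond the scatter is expected in this assay. The expected change is small: a 1.2-fold lower number from compound 1 to compound 4 (0.07 log units; within the scatter). Compound 4 is estimated at 750 nM, within an expected range of 280 nM to 2000 nM.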

Compound 4, half-maximal inhibitory concentration: 880 nM
Beside the measured number, compound 4's estimate is 1.2-fold (0.07 log units) below it, within the range that was stated.
By their numbers in this assay, from the lowest: compound 3; then compounds 2, 1 and 4 (each within the scatter of the next).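

In this assay, for the compounds shown here, 5-methylthiophen-2-yl in place of furan-2-yl gives no change at the digits printed from compound 1 to compound 4 (within the scatter) and is the first step that changes only this position on the shared core. At this position, the number therefore holds when one five-membered aromatic ring with 1 hetero atom replaces another and the entering ring carries a methyl group. Nothing measured here explains this result.

As far as these compounds go, the sulfur and the methyl group enter together, so their separate contributions remain open. Also open, from the compounds shown here alone, is whether an amine, a carboxylic acid or a phenyl ring here would leave the number unchanged.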